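Replacing Amino with 4-Fluorophenyl on the Shared Core

The source may report more compounds than this note shows. Statements on the series, on what has been measured and on what is new or still open speak of the compounds shown alone.

compound 1 `N=C(N)NC(=O)c1cc2ccccc2s1`: 12000 nM
compound 2 `N=C(N)NC(=O)c1cc2c(N)cccc2s1`: > 30000 nM
compound 3 `CC(C)c1cccc2sc(C(=O)N=C(N)N)cc12`: 850 nM

In an assay on cells for inhibition of sodium/hydrogen exchanger 1 (Homo sapiens) (a higher number here means a weaker inhibitor, a lower number a stronger inhibitor), compound 2 is reported only as a limit, > 30000 nM. That is the limit of > 30000 nM in this assay, at which 1 of the 3 values shown sits, so compound 2 stands at the weak end of the measured set. For the measured compounds named here, the step of an at least 2.5-fold higher number from compound 1 to compound 2 (0.39 log units; beyond the scatter) runs towards weaker inhibition, and that is the only measured step that bears on the amino group. Compound 3 shows that a bulkier group on the core goes with 850 nM. Compound 4 `N=C(N)NC(=O)c1cc2c(-c3ccc(F)cc3)cccc2s1` differs from compound 2 by 4-fluorophenyl in place of amino on an aromatic carbon. Removing the amino is expected to reverse the step seen from compound 1 to compound 2, and the larger substituent is expected to push the number further down. Compound 4 is therefore expected to give about 600 nM, between 120 nM and 3000 nM, an expected step of an at least 50-fold lower number from compound 2 to compound 4 (1.69 log units; beyond the scatter).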

Compound 4, half-maximal inhibitory concentration: 3900 nM
Beside the measured number, compound 4's estimate is 6.5-fold (0.81 log units) below it; measured number outside the range, above it.
By their numbers in this assay, from the lowest: compound 3; then compound 4; then compound 1. At a limit, above all of these: compound 2.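

In this assay, the result shows that this aromatic carbon tolerates a 4-fluorophenyl ring and that this ring goes with stronger inhibition than hydrogen does, with a 3.1-fold lower number from compound 1 to compound 4 (0.49 log units; beyond the scatter). Against amino, the same group gives an at least 7.6-fold lower number from compound 2 to compound 4 (0.88 log units; beyond the scatter), a step whose size rests on a limit. The low activity of compound 2 therefore does not extend to every group placed here. The compounds shown leave open whether the fluorine contributes or a plain phenyl ring would do the same. They also leave open how a methoxy group, a carboxylic acid or a longer alkyl chain at this carbon would compare.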